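Trimming the hydroxy: what to expect of compound 3

The compounds below may be only part of what the source reports. "The series", "measured", "known", "first", "only" and "open" are said of these compounds alone.

Compound 2 `COc1ccc(C[S+]([O-])c2ncccc2C(=O)Nc2ccncc2)c(OCCO)c1` is the shorter-lived of the two measured compounds: in an ADME assay (on this read-out higher numbers stand for a longer-lived compound and lower numbers for a shorter-lived compound), compound 2 gives 1.78 h, whereas compound 1 `COc1ccc(C[S+]([O-])c2ncccc2C(=O)Nc2ccncc2)c(OC)c1OC` gives 116 h, a gap well beyond the scatter. Compound 3 `CCOc1cc(OC)ccc1C[S+]([O-])c1ncccc1C(=O)Nc1ccncc1` differs from compound 2 only by hydrogen in place of hydroxy on a saturated chain carbon, two bonds along the chain from an oxygen on an aromatic ring. Among the measured compounds shown here, no measured pair shows this exact change, so the direction rests on compound 1, which carries no hydroxy and gives 116 h. An increase is expected, a 6.7-fold higher number from compound 2 to compound 3 (0.83 log units; beyond the scatter), though its size is uncertain. Compound 3 is therefore estimated at 12 h, with a likely range from 2.5 h to 60 h.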

Compound 3, half-life: 0.71 h
Compound 3: the middle estimate sits 17-fold (1.23 log units) above what was measured; the whole stated range lies above it.
By their numbers in this assay, from the lowest: compound 3; then compound 2; then compound 1.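

In this assay, among the compounds shown here, going from 2-hydroxyethoxy to ethoxy gives a 2.5-fold lower number from compound 2 to compound 3 (0.40 log units; beyond the scatter) and so provides the first single-place step at this position. Removing the hydroxy from this chain does not raise the number here; the modest change runs downward. Nothing available bears on why the step runs this way. As far as these compounds go, whether an amine or a carboxylic acid in place of the hydroxy, or a longer chain, would raise or lower the number remains open. So does whether this step would hold with the other substituents of compound 1 on the ring.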